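This account rests on a few compounds, and the source may have more. Where it says the series, first, only, none or still open, it means among the compounds named here.

Three compounds share one core and differ only in the group at the end of the chain. Compound 1 (`COC1=C(C)C(=O)/C(=C(O)/C=C/c2ccc(OC)cc2)C(=O)C1(C)C`) carries a 4-methoxyphenyl group, compound 2 (`COC1=C(C)C(=O)/C(=C(O)/C=C/c2cccc(OC)c2)C(=O)C1(C)C`) a 3-methoxyphenyl group and compound 3 (`COC1=C(C)C(=O)/C(=C(O)/C=C/c2ccccc2OC)C(=O)C1(C)C`) a 2-methoxyphenyl group. In a functional assay on HUVEC cells (Homo sapiens) for cytotoxicity (a lower number here means that less compound is needed, a higher number that more compound is needed for the effect), compound 1 gives 2.5 ug/mL and compound 2 gives 1.6 ug/mL while compound 3 gives 1.7 ug/mL so compound 1 stands within the scatter of the other two.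

Compound 4 (`COC1=C(C)C(=O)/C(=C(O)/C=C/c2ccc(F)cc2)C(=O)C1(C)C`) has not yet been measured. The change from compound 1 (fluoro in place of methoxy on an aromatic carbon) puts fluoro in place of methoxy on an aromatic carbon, para to a large group. The nearest evidence comes from moving the methoxy group, with a 1.6-fold lower number from compound 1 to compound 2 (0.19 log units; within the scatter) and a 1.5-fold lower number from compound 1 to compound 3 (0.17 log units; within the scatter) as the two steps available. Going by the values given here, no measured compound carries fluoro, so these steps offer only a rough guide. The step expected here is a 1.1-fold lower number from compound 1 to compound 4 (0.06 log units; within the scatter) which means no change beyond the scatter and no firm direction. Compound 4 is estimated at 2.2 ug/mL in this assay with 1 ug/mL to 5 ug/mL as the expected range.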

Compound 4, concentration for half-maximal effect: 2 ug/mL
For compound 4 the middle estimate is 1.1-fold (0.04 log units) above the measured one; measured number inside the range.
By their numbers in this assay, from the lowest: compounds 2, 3, 4 and 1 (each within the scatter of the next).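

The earlier compounds shown here only moved the methoxy group around the ring, whereas compound 4 replaces it with fluoro on an aromatic carbon, para to a large group, and in this assay this gives a 1.3-fold lower number from compound 1 to compound 4 (0.10 log units; within the scatter) as the step. Compound 4 also stays within the scatter of the two compounds with the methoxy group elsewhere, with a 1.2-fold higher number from compound 3 to compound 4 (0.07 log units; within the scatter) and a 1.3-fold higher number from compound 2 to compound 4 (0.10 log units; within the scatter) as the steps, so exchanging methoxy for fluoro at this position leaves no change that can be told from the scatter. No other measurement here helps to explain this result.

As far as these compounds go, it remains open whether an amine or a carboxylic acid at this position would give a step beyond the scatter. From the compounds shown here alone, how fluoro behaves elsewhere on the ring also remains open.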